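The compounds below may be only part of what the source reports. "The series", "measured", "known", "first", "only" and "open" are said of these compounds alone.

Measured compounds in a functional assay on HOP-92 cells (Homo sapiens) for cytotoxicity, read by sulforhodamine B assay, with a stated time of 48 h, tested at 100 nM; on this read-out higher numbers stand for a weaker effect at the one concentration tested and lower numbers for a stronger effect:
- compound 1 `COc1cc(C)cc(-c2c(-c3ccnc(-c4ccc(C(C)=O)cc4)c3)cnn2CC#N)c1`: 61%
- compound 2 `COc1cc(C)cc(-c2nn(CC#N)cc2-c2ccc(-c3cccc(C(C)=O)c3)nc2)c1`: 89%
- compound 3 `Cc1cc(O)cc(-c2nn(CC#N)cc2-c2ccnc(-c3ccc(Oc4ccccc4)cc3)c2)c1`: 70%

Compound 3 stands second highest of the three numbers. Its reading and that of compound 1 lie within the scatter of each other, so nothing separates them here. Compound 2 gives a higher number than compound 3, and that gap lies beyond the scatter.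

Compound 4 `Cc1cc(O)cc(-c2nn(CC#N)cc2-c2ccnc(-c3ccc(N(C)C)cc3)c2)c1` is not yet measured. It differs from compound 3 in one place: dimethylamino in place of phenoxy on an aromatic carbon

Among the measured compounds shown here, no pair of measured compounds in this set differs in exactly one place, so there is no measured step against which to weigh this change. The shared core and the nitrile-bearing chain are kept, and only the group on the far aromatic ring is exchanged. With nothing in the set to point either way, the expected step in this assay is none beyond the scatter, in no particular direction.

For compound 4 the expected reading in this assay is 72%, with a range of 50% to 92%, which corresponds to an expected step of a number 2 percentage points higher from compound 3 to compound 4 (within the scatter).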

Compound 4, a percentage reported as activity, at one concentration (the size of the read-out at that concentration, not a potency): 73%
Beside the measured number, compound 4's estimate is 1 percentage points below it; the range from low to high includes it.
By their numbers in this assay, from the lowest: compounds 1, 3 and 4 (each within the scatter of the next, the first and the last beyond it); then compound 2.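

In this assay, dimethylamino in place of phenoxy, on an aromatic carbon para to a large group, gives a number 3 percentage points higher from compound 3 to compound 4 (within the scatter), the first one-place step available in this series. At this one concentration, the reading therefore does not separate phenoxy, with its six-membered aromatic ring of carbon only and 7 heavy atoms, from dimethylamino, with no ring and 3 heavy atoms. Nothing available bears on why the two readings stand so close.

This single step leaves open how other groups at this position would read, such as a primary amine, a carboxylic acid or a longer chain like butoxy. It also leaves open whether the same exchange would read alike on the core of compound 1.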